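The source may report more compounds than this note shows. Statements on the series, on what has been measured and on what is new or still open speak of the compounds shown alone.

Of the compounds shown here, three built on one shared core have been measured in a functional assay on DLD-1 cells (Homo sapiens) for antiproliferative activity, read by CellTiter-Glo, with a stated time of 72 h; a higher number here means a weaker inhibitor, a lower number a stronger inhibitor. Compound 1 `CC1CCN(C2CCN(S(=O)(=O)c3cccc(-c4ccccc4C(F)(F)F)c3)CC2)CC1` gives 10 nM. Compound 2 `CC1CCN(C2CCN(S(=O)(=O)c3cccc(-c4ccccc4F)c3)CC2)CC1` gives 10 nM. Compound 3 `CC1CCN(C2CCN(S(=O)(=O)c3ccc(F)cc3F)CC2)CC1` gives 102 nM. Compound 2 therefore stands level with compound 1, and the two together occupy the low end of the three numbers, while compound 3 lies well apart from them, beyond the scatter.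

Among the compounds with values here, only one measured step joins two neighbours: no change at the digits printed from compound 1 to compound 2 (within the scatter). That swap on an aromatic carbon left the number untouched.

Compound 4 `CC1CCN(C2CCN(S(=O)(=O)c3cccc(-c4ccc(Cl)cc4)c3)CC2)CC1` differs from compound 2 by 4-chlorophenyl in place of 2-fluorophenyl on an aromatic carbon. Within the data shown here, no measured step covers this exact change, so the flat step from compound 1 to compound 2 is the nearest guide, and it suggests that altering the group on this aromatic carbon need not move the number much. A small rise, possibly none beyond the scatter, is expected, so a 2.0-fold higher number from compound 2 to compound 4 (0.30 log units; within the scatter) is the estimated step. Compound 4 is expected to give about 20 nM, within a range from 5 nM to 80 nM.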

Compound 4, half-maximal inhibitory concentration: 15 nM
Compound 4: middle estimate off by 1.3-fold (0.12 log units), on the high side; low and high end bracket the measured number.
By their numbers in this assay, from the lowest: compounds 1, 2 and 4 (each within the scatter of the next); then compound 3.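

Within the data shown here, until now, the only groups compared on this aromatic carbon were 2-(trifluoromethyl)phenyl and 2-fluorophenyl, both with a substituent at the 2-position of their ring. 4-Chlorophenyl brings a different halogen at a different ring position, yet this assay shows a 1.5-fold higher number from compound 2 to compound 4 (0.18 log units; within the scatter) and a 1.5-fold higher number from compound 1 to compound 4 (0.18 log units; within the scatter), so across compounds 1, 2 and 4 the number holds steady through a wider range of substituted phenyl groups than the first pair covered. No supporting measurement is available to explain why these three groups read alike.

This swap changes the halogen and its ring position together, so the compounds shown cannot separate the two. From the compounds shown here alone, whether the number stays this flat with an unsubstituted phenyl, or with a phenyl carrying an amine or a carboxylic acid, remains open.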